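The source may report more compounds than this note shows. Statements on the series, on what has been measured and on what is new or still open speak of the compounds shown alone.

The three measured compounds share one core and differ only in the group on one aromatic carbon. In a functional assay on PC-3 cells (Homo sapiens) for inhibition, read by sulforhodamine B assay, with a stated time of 48 h, tested at 10 uM (on this read-out lower numbers stand for less inhibition and higher numbers for more inhibition at the one concentration tested (going by the name of the read-out)), compound 1 `Brc1cn2ccnc2c(-c2ccc3ncn(C4CCCCC4)c3c2)n1` gives 17.2%, compound 2 `c1ccc(-c2cn3ccnc3c(-c3ccc4ncn(C5CCCCC5)c4c3)n2)cc1` gives 92%, and compound 3 `O=Cc1ccc(-c2cn3ccnc3c(-c3ccc4ncn(C5CCCCC5)c4c3)n2)cc1` gives 19%. Compound 3 thus stands second highest of the three, with compound 1 a near neighbour and compound 2 far above it. Compound 4 `c1ccc2c(-c3cn4ccnc4c(-c4ccc5ncn(C6CCCCC6)c5c4)n3)cccc2c1` has not yet been measured; it carries naphthalen-1-yl in place of 4-formylphenyl on an aromatic carbon. For the measured compounds named here, two measured steps bear on this change: a number 73 percentage points lower from compound 2 to compound 3 (beyond the scatter), and a number 74.8 percentage points higher from compound 1 to compound 2 (beyond the scatter). Going by the values given here, compound 2, with a plain phenyl, gives 92% while the formyl-bearing compound 3 gives 19%; removing the formyl and enlarging the group to naphthalen-1-yl is therefore expected to raise inhibition substantially, though a second fused ring has no measured precedent, so the range is wide. For compound 4 the expected step is a number 46 percentage points higher from compound 3 to compound 4 (beyond the scatter). Compound 4 is therefore estimated at 65%, between 25% and 95%.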

Compound 4, a percentage reported as inhibition, at one concentration (the size of the read-out at that concentration, not a potency): 36.5%
The estimate for compound 4 lay 28.5 percentage points above the measured number; low and high end bracket the measured number.
By their numbers in this assay, from the lowest: compounds 1 and 3 (each within the scatter of the next); then compound 4; then compound 2.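

In this assay the change from phenyl to naphthalen-1-yl is a number 55.5 percentage points lower from compound 2 to compound 4 (beyond the scatter) and so a second fused aromatic ring at this position gives up much of what phenyl gained over bromo. Part of that gain survives, as seen in a number 19.3 percentage points higher from compound 1 to compound 4 (beyond the scatter) against bromo and in a number 17.5 percentage points higher from compound 3 to compound 4 (beyond the scatter) against 4-formylphenyl. Among these four compounds, then, an aromatic group of carbon only at this position does not by itself bring high inhibition: phenyl does, while naphthalen-1-yl does so only in part.

From the compounds shown here alone, whether other groups here, such as a pyridyl ring, a 4-methoxyphenyl or an amine, would fall nearer to phenyl or to naphthalen-1-yl stays open. Nothing shown here explains the differences between these groups.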